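The compounds below may be only part of what the source reports. "The series", "measured", "known", "first", "only" and "open" are said of these compounds alone.

Of the compounds shown here, three sharing one core have been measured so far. Compound 1 `Cc1cc(C)n(CCOC2CC(=O)Nc3c2c(C)nn3-c2ncnc3nc[nH]c23)n1` gives 16 nM in a functional assay on HEK293 cells for agonist activity at G-protein coupled receptor 39 (Homo sapiens), read by scintillation proximity assay and inositol phosphate accumulation, with a stated time of 75 min, in the presence of a further agent that is not named here; a higher number here means that more compound is needed for the effect, a lower number that less compound is needed. Compound 2 `Cc1nn(-c2ncnc3nc[nH]c23)c2c1C(OCc1ccccc1C#N)CC(=O)N2` gives 8 nM in the same assay, and compound 3 `Cc1nn(-c2ncnc3nc[nH]c23)c2c1C(NC(=O)Cc1cccs1)CC(=O)N2` gives 3 nM. Compound 3 therefore stands at the lowest number of the three: the change from compound 1 to compound 3 brought a 5.3-fold lower number from compound 1 to compound 3 (0.73 log units; beyond the scatter), and that from compound 2 to compound 3 brought a 2.7-fold lower number from compound 2 to compound 3 (0.43 log units; beyond the scatter), both beyond the scatter.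

Compound 4 `Cc1nn(-c2ncnc3nc[nH]c23)c2c1C(OCc1ccccc1Cl)CC(=O)N2` has not yet been measured. It differs from compound 3 in one place: (2-chlorobenzyl)oxy in place of (((thiophen-2-yl)methyl)carbonyl)amino on a saturated ring carbon. Among the measured compounds shown here, the step that bears most directly on this change is the one from compound 2 to compound 3, since compound 2 also carries a benzyl ether on the same saturated ring carbon, with a nitrile where compound 4 carries a chlorine. Going from compound 3 to compound 4 largely reverses that step, so the number is expected to move back up toward the value of compound 2, though a chlorine in place of a nitrile may shift it somewhat either way.

On that basis compound 4 is expected to give about 12 nM, with a likely range from 4 nM to 40 nM, which would mean an expected step of a 4.0-fold higher number from compound 3 to compound 4 (0.60 log units; beyond the scatter).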

Compound 4, half-maximal effective concentration: 2 nM
Compound 4: middle estimate off by 6.0-fold (0.78 log units), on the high side; the measured number lies below the stated range.
By their numbers in this assay, from the lowest: compounds 4 and 3 (each within the scatter of the next); then compounds 2 and 1 (each within the scatter of the next).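

On the saturated ring carbon, an ether and an amide now stand level in this assay: a 1.5-fold lower number from compound 3 to compound 4 (0.18 log units; within the scatter) replaces the (((thiophen-2-yl)methyl)carbonyl)amino group with (2-chlorobenzyl)oxy, so the gap seen earlier between the amide and the only benzyl ether then available does not hold for benzyl ethers in general. The earlier compounds could not show how much the substituent on the benzyl ring matters, but a 4.0-fold lower number from compound 2 to compound 4 (0.60 log units; beyond the scatter) isolates chloro in place of cyano on an aromatic carbon as a single change beyond the scatter, and an 8.0-fold lower number from compound 1 to compound 4 (0.90 log units; beyond the scatter) puts 2-chlorophenyl in place of (3,5-dimethyl-1H-pyrazol-1-yl)methyl, the widest gap among the ethers shown. Nothing given here accounts for the difference between the chloro and the cyano compound.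

With a single pair, the compounds shown leave open whether the chloro over cyano difference would carry over to any other ether on this carbon. They also leave open whether a methoxy or a trifluoromethyl in place of the chloro would hold the number, and whether a plain amine on the saturated ring carbon would do so.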